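Cyclopropyl for Methyl and Oral Exposure in Rats

A few compounds are considered here, and "the series" means these few. Any claim that something is new, unique, unknown or untested is made for them only; others in the source may bear on it.

Four macrocyclic acylsulfonamides are compared in an ADME assay on the whole organism for pharmacokinetics, with Rattus norvegicus as the target, with a stated time of 24 h, at a dose of 5 mg/kg by the oral route; on this read-out higher numbers stand for higher exposure at the dose given and lower numbers for lower exposure. Compound 1 `Cc1nc2ccccc2c2c1O[C@]1(CC2)C[C@H]2C(=O)N[C@]3(C(=O)NS(=O)(=O)C4(C)CC4)C[C@H]3/C=C\CCCCC[C@H](NC(=O)OC(C)(C)C)C(=O)N2C1` carries a methyl group on its core, and in this assay compound 1 gives 105 ng.h/mL. Compound 2 `CC(C)(C)OC(=O)N[C@H]1CCCCC/C=C\[C@@H]2C[C@@]2(C(=O)NS(=O)(=O)C2(C)CC2)NC(=O)[C@@H]2C[C@]3(CCc4c(c(C5CC5)nc5ccccc45)O3)CN2C1=O` differs from it by one change, (cyclopropyl in place of methyl on an aromatic carbon), and in this assay compound 2 gives 1550 ng.h/mL. The step of a 15-fold higher number from compound 1 to compound 2 (1.17 log units; beyond the scatter) is the only measured step of this kind among the compounds shown.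

Compound 3 `COc1ccc2nc(C)c3c(c2c1)CC[C@]1(C[C@H]2C(=O)N[C@]4(C(=O)NS(=O)(=O)C5(C)CC5)C[C@H]4/C=C\CCCCC[C@H](NC(=O)OCC(C)C)C(=O)N2C1)O3` is built on a second core; the difference between the two cores is not broken down here. In this assay compound 3 gives 101 ng.h/mL, a number that lies within the scatter of the value of compound 1, so the two cannot be told apart on this read-out.

Compound 4 `COc1ccc2nc(C3CC3)c3c(c2c1)CC[C@]1(C[C@H]2C(=O)N[C@]4(C(=O)NS(=O)(=O)C5(C)CC5)C[C@H]4/C=C\CCCCC[C@H](NC(=O)OCC(C)C)C(=O)N2C1)O3` has not yet been measured. It differs from compound 3 by cyclopropyl in place of methyl on an aromatic carbon, and the place of the change is described in the same words as for the pair of compound 1 and compound 2, so it is the same change carried onto the second core.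

The expectation for compound 4 rests on a single pair. Because the step of a 15-fold higher number from compound 1 to compound 2 (1.17 log units; beyond the scatter) was large and compound 3 starts from a value close to that of compound 1, compound 4 is expected to rise by roughly an 8.9-fold higher number from compound 3 to compound 4 (0.95 log units; beyond the scatter). The estimate is that compound 4 will give about 900 ng.h/mL, likely falling between 250 ng.h/mL and 3000 ng.h/mL.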

Compound 4, area under the concentration-time curve: 1850 ng.h/mL
Estimate against measurement, compound 4: 2.1-fold (0.31 log units) below; the range from low to high includes it.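

In this assay, cyclopropyl in place of methyl on an aromatic carbon, next to the ring nitrogen, gives an 18-fold higher number from compound 3 to compound 4 (1.26 log units; beyond the scatter) on the second core, a large rise that matches the one on the first core. The change therefore carries from one core to the other in this series, and the size of the rise cannot be told apart between the two cores: the same change on two cores in this assay, a 15-fold higher number (1.17 log units; beyond the scatter) from compound 1 to compound 2 and an 18-fold higher number (1.26 log units; beyond the scatter) from compound 3 to compound 4, 1.2-fold (0.09 log units) apart, within the scatter of two such steps

This rests on just two matched pairs, all in one read-out at one oral dose in one species, so it does not show why exposure rises or that the same rise would appear on any further core.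

The compounds shown leave open whether a different group on the same aromatic carbon, such as an open chain like ethyl or isopropyl or a larger ring like cyclobutyl, would go with a rise of this size. Within the data shown here, they also leave open which of the features that separate the two cores, the methoxy group or the carbamate chain, would alter the step if changed alone, as no pair here isolates either one.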